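The source may hold more compounds than are shown below. What is called first, only, known or untested is meant among the compounds shown, and "the series" means these compounds.

Measured compounds:
compound 1, `Cc1ccc(C(=O)Nc2cccc(-c3oc4cc(-c5ccc(F)cc5)ccc4c(=O)c3O)c2)cc1`, gives 4350 nM
compound 2, `Cc1ccccc1C(=O)Nc1cccc(-c2oc3cc(-c4ccc(F)cc4)ccc3c(=O)c2O)c1`, gives 4910 nM
compound 3, `COc1cc(OC)cc(C(=O)Nc2cccc(-c3oc4cc(-c5ccc(F)cc5)ccc4c(=O)c3O)c2)c1`, gives 4040 nM

All three share one core and differ only in the aryl group on the carbonyl carbon of the amide. In a functional assay on MDA-MB-231 cells (Homo sapiens) for antiproliferative activity, read by CCK-8 assay, with a stated time of 72 h (a lower number here means a stronger inhibitor, a higher number a weaker inhibitor), compound 2 carries the highest of the three numbers, yet the gaps are small: a 1.1-fold higher number from compound 1 to compound 2 (0.05 log units; within the scatter) and a 1.2-fold lower number from compound 2 to compound 3 (0.08 log units; within the scatter) both lie within the scatter, so the three compounds cannot be told apart. Compound 4, `O=C(Nc1cccc(-c2oc3cc(-c4ccc(F)cc4)ccc3c(=O)c2O)c1)c1cc(F)cc(F)c1`, is not yet measured. Its change from compound 2 is 3,5-difluorophenyl in place of 2-methylphenyl on a carbonyl carbon. The two aryl swaps already seen at this carbonyl carbon moved nothing beyond the scatter. The expected step is therefore none beyond the scatter: a 1.1-fold lower number from compound 2 to compound 4 (0.04 log units; within the scatter). Compound 4 is estimated at 4500 nM, within 2200 nM to 9000 nM.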

Compound 4, half-maximal inhibitory concentration: 2440 nM
For compound 4 the middle estimate is 1.8-fold (0.27 log units) above the measured one; measured number inside the range.
By their numbers in this assay, from the lowest: compounds 4, 3, 1 and 2 (each within the scatter of the next).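

Going by these compounds alone, with 3,5-difluorophenyl on the carbonyl carbon, the first fluorine-bearing aryl group at this position, every step in this assay stays within the scatter (a 2.0-fold lower number from compound 2 to compound 4 (0.30 log units; within the scatter)) (a 1.7-fold lower number from compound 3 to compound 4 (0.22 log units; within the scatter)) (a 1.8-fold lower number from compound 1 to compound 4 (0.25 log units; within the scatter)). Across all four compounds, then, this position accepts methyl-, methoxy- and fluorine-bearing phenyl groups with no step that can be told from noise. Nothing measured here bears on what lies behind these numbers. Still open, from the compounds shown here alone, is whether an amine, a carboxylic acid or a longer chain in place of the aryl ring would move the number beyond the scatter.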